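Tetrazole for dimethylamino on the pendant phenyl ring

This account rests on a few compounds, and the source may have more. Where it says the series, first, only, none or still open, it means among the compounds named here.

Compound 2 `CCCS(=O)(=O)Nc1ccc(F)c(C(=O)c2n[nH]c3ncc(-c4ccc(N(C)C)cc4)cc23)c1F` belongs to a series of three measured compounds that share one core and differ only in the aryl group attached to it. In an assay for binding affinity to dual specificity mitogen-activated protein kinase kinase 4 (Homo sapiens), read by KINOMEscan, tested at 100 nM (a higher number here means a weaker effect of the compound at the concentration tested, a lower number a stronger effect), compound 2 gives 2.5%. Compound 1 `CCCS(=O)(=O)Nc1ccc(F)c(C(=O)c2n[nH]c3ncc(-c4ccccc4OC)cc23)c1F` gives 1.9% in this assay, and compound 3 `CCCS(=O)(=O)Nc1ccc(F)c(C(=O)c2n[nH]c3ncc(-c4ccc(C)c(C)c4)cc23)c1F` gives 20%. Compound 2 thus sits within the scatter of compound 1, while its gap to compound 3 is real: a number 17.5 percentage points higher from compound 2 to compound 3 (beyond the scatter). The other measured steps are a number 0.6 percentage points higher from compound 1 to compound 2 (within the scatter) and a number 18.1 percentage points higher from compound 1 to compound 3 (beyond the scatter).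

Compound 4 `CCCS(=O)(=O)Nc1ccc(F)c(C(=O)c2n[nH]c3ncc(-c4ccc(-c5nnn[nH]5)cc4)cc23)c1F` has not yet been measured. It differs from compound 2 by one change (1H-tetrazol-5-yl in place of dimethylamino on an aromatic carbon). Going by the values given here, no measured step swaps a group for a tetrazolyl, so the closest guide is how the aryl substituent pattern mattered so far: compounds 1 and 2, each with a single heteroatom-bearing group on the phenyl ring, stayed within the scatter of each other, and only the dimethyl-substituted compound 3 moved beyond it. A group that keeps a hydrogen-bond acceptor at the same place of the ring is therefore expected to shift this assay little, with the step estimated as a number 2.5 percentage points higher from compound 2 to compound 4 (within the scatter). Compound 4 is expected to give about 5%, most likely between 1% and 25%.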

Compound 4, a percentage reported as activity, at one concentration (the size of the read-out at that concentration, not a potency): 0.15%
The estimate for compound 4 lay 4.9 percentage points above the measured number; measured number below the stated range.
By their numbers in this assay, from the lowest: compounds 4, 1 and 2 (each within the scatter of the next); then compound 3.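

In this assay, putting 1H-tetrazol-5-yl in place of dimethylamino gives a number 2.4 percentage points lower from compound 2 to compound 4 (within the scatter), so on this phenyl ring, para to a large group, a five-membered aromatic ring with 4 hetero atoms and a hydrogen-bond donor can replace a small group with no ring and no donor without a change beyond the scatter. Going by these compounds alone, the comparison with the other aryl groups gives a number 1.8 percentage points lower from compound 1 to compound 4 (within the scatter) and a number 19.9 percentage points lower from compound 3 to compound 4 (beyond the scatter), which leaves 3,4-dimethylphenyl in compound 3 as the only aryl group set apart from the rest, while 2-methoxyphenyl, 4-(dimethylamino)phenyl and 4-(1H-tetrazol-5-yl)phenyl cannot be told apart in this assay. Nothing available here accounts for why these aryl groups read alike or why compound 3 differs.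

The compounds shown leave open whether the hydrogen on the tetrazole matters, which a methyl group on that ring would test, and whether a carboxylic acid at the same place would read like the tetrazole. They also leave open whether a single methyl group on the phenyl ring would read like compound 3, and these single-concentration numbers do not give potencies.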